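A few compounds are considered here, and "the series" means these few. Any claim that something is new, unique, unknown or untested is made for them only; others in the source may bear on it.

Series notes. Of the compounds shown here, two of a shared core have been measured so far. Compound 1, `COc1ccc(-n2cc3nc(C)nc(NC(=O)Nc4ccccc4)c3n2)cc1`, and compound 2, `COc1ccc(-n2cc3nc(Cc4ccccc4)nc(N)c3n2)cc1`, were both run in an assay on CHO cells for displacement of a labelled ligand from adenosine receptor A1 (Homo sapiens), read by scintillation counting, with a stated time of 120 min, tested at 1 uM; a lower number here means less inhibition, a higher number more inhibition at the concentration tested (going by the name of the read-out). In this assay compound 1 gives 5%. In this assay compound 2 gives 40%, the higher of the two numbers, and its gap to compound 1 lies beyond the usual scatter of repeats. Among the measured compounds shown here, no step between the two is set out; they differ at more than one place, so only their two values are put side by side.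

Compound 3, `COc1ccc(-n2cc3nc(C)nc(N)c3n2)cc1`, has not yet been measured in this assay. It differs from compound 2 in one place: hydrogen in place of phenyl on a saturated chain carbon bound to an aromatic carbon. Compound 1 carries the same methyl at that place but also differs from compound 3 elsewhere, so its number does not stand alone as a guide to this change.

For the measured compounds named here, no measured step covers this change. The step from the estimate is a number 20 percentage points lower from compound 2 to compound 3 (beyond the scatter), expected downward and beyond the scatter. Compound 3 is expected to give 20% in this assay, within 5% to 40%.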

Compound 3, a percentage reported as inhibition, at one concentration (the size of the read-out at that concentration, not a potency): 30%
Compound 3: the middle estimate sits 10 percentage points below what was measured, and the stated range covers the measured number.
By their numbers in this assay, from the lowest: compound 1; then compounds 3 and 2 (each within the scatter of the next).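

In this assay, the change from phenyl to hydrogen on a saturated chain carbon bound to an aromatic carbon, which also reads as benzyl to methyl, gives a number 10 percentage points lower from compound 2 to compound 3 (within the scatter), so benzyl and methyl cannot be told apart at this place in this read-out. The change from phenylcarbamoyl to hydrogen on a nitrogen on an aromatic ring, with the methyl held in common, gives a number 25 percentage points higher from compound 1 to compound 3 (beyond the scatter), which makes this nitrogen the one place among the compounds shown where a single change separates two numbers, though only modestly. No supporting evidence bears on either step, so both stand as bare observations.

Still open, on these data alone, is how the chain carbon responds to groups other than benzyl and methyl, such as a longer chain like propyl or a carboxylic acid, and how the nitrogen responds to a smaller acyl group such as acetyl in place of phenylcarbamoyl. The compounds shown also leave open whether phenylcarbamoyl on the nitrogen gives a similar step when benzyl rather than methyl sits on the core.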